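A few compounds are considered here, and "the series" means these few. Any claim that something is new, unique, unknown or untested is made for them only; others in the source may bear on it.

Compound 1 `COc1cc(N2C(N)=C(C#N)C(c3ccc([N+](=O)[O-])cc3)C3=C2CC(C)(C)CC3=O)cc(OC)c1OC`: 10%
Compound 2 `COc1cc(N2C(N)=C(C#N)C(c3ccccc3Cl)C3=C2CC(C)(C)CC3=O)cc(OC)c1OC`: 10%

In a functional assay on Ehrlich cells (Mus musculus) for cytotoxicity, tested at 10 ug/mL (a higher number here means a stronger effect of the compound at the concentration tested, a lower number a weaker effect), compound 1 gives 10% and stands level with compound 2, which gives 10%. Among the measured compounds shown here, the single measured step, no change at the digits printed from compound 1 to compound 2 (within the scatter), concerns a 2-chlorophenyl in place of 4-nitrophenyl on a saturated ring carbon. Compound 3 `COc1cc(N2C(N)=C(C#N)C(c3ccc(O)cc3)C3=C2CC(C)(C)CC3=O)cc(OC)c1OC` differs from compound 1 by hydroxy in place of nitro on an aromatic carbon, read one bond further out as 4-nitrophenyl to 4-hydroxyphenyl. For the measured compounds named here, no measured step covers this exchange; the one step known shows no change within the scatter, and both measured values are low. Accordingly no change at the digits printed from compound 1 to compound 3 (within the scatter) is expected to stay within the scatter. For compound 3 the estimate is 10%, ranging from 0% to 25%.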

Compound 3, a percentage reported as activity, at one concentration (the size of the read-out at that concentration, not a potency): 10%
Compound 3: middle estimate and measured number agree at the digits printed, and the stated range covers the measured number.
By their numbers in this assay, from the lowest: compounds 1, 2 and 3 (each within the scatter of the next).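

In this assay there is now a reading for an exchange on the aromatic carbon itself, with no change at the digits printed from compound 1 to compound 3 (within the scatter) for hydroxy in place of nitro, a group with a hydrogen-bond donor replacing one without. The change of whole aryl group agrees, with no change at the digits printed from compound 2 to compound 3 (within the scatter) for 4-hydroxyphenyl in place of 2-chlorophenyl, so the three groups shown stand within the scatter of one another. From the compounds shown here alone, whether an amine or a carboxylic acid at this place would give a different read-out remains open, as do changes elsewhere on the shared core. No measurement is available that could explain these results.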